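The compounds below may be only part of what the source reports. "The series", "measured", "known", "first", "only" and "open" are said of these compounds alone.

Three compounds from this series have been run in a functional assay on A549 cells (Homo sapiens) for cytotoxicity, read by MTT assay, with a stated time of 24 h; on this read-out higher numbers stand for weaker inhibition and lower numbers for stronger inhibition. Going by the values given here, compound 1 `C=CC1=C(C(=O)NCc2ccccc2)C(c2ccc(OC)c(OC)c2)OC1` is the first of them. In this assay compound 1 gives > 100000 nM, which is a limit of the assay and not a number. Compound 2 `C=CC1=C(C(=O)NCCCCC)C(c2ccc(Cl)c(Cl)c2)OC1` carries a pentylamino on the carbonyl carbon. In this assay compound 2 gives > 100000 nM, again a limit of the assay rather than a measured number. Compound 3 `C=CC1=C(C(=O)NC2CCCCC2)C(c2ccc(OC)cc2)OC1` completes the measured set. In this assay compound 3 gives > 100000 nM, which is also a limit. Where compound 2 stands is therefore simple to state: it sits at the limit of > 100000 nM in this assay, at which 3 of the 3 values shown sit, and no ordering among the three can be drawn from such values.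

Compound 4 `C=CC1=C(C(=O)O)C(c2ccc(Cl)c(Cl)c2)OC1` has not yet been measured in this assay. It differs from compound 2 in one place: hydroxy in place of pentylamino on a carbonyl carbon. Among the compounds with values here, no measured step in this set shows what such a change does, and the three values all sit at the same limit. The step from compound 2 to compound 4 is expected to be a step that the limit leaves unreadable from compound 2 to compound 4, which is to say no shift beyond the scatter. Compound 4 is therefore expected to give about 150000 nM in this assay, in a range from 50000 nM to 500000 nM, most likely reported only as a limit.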

Compound 4, half-maximal inhibitory concentration: > 100000 nM
Compound 4: no number, only a limit; the forecaster's own chance of this, stated with the estimate: 85%; the middle value does not contradict the limit.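

Compound 2 and compound 4 both give only a limit in this assay, so the exchange of pentylamino for hydroxy on the carbonyl carbon cannot be read as a step: the limit of > 100000 nM in this assay, at which 4 of the 4 values shown sit.

The compounds shown leave open whether any change to this series would yield a measured number in this assay, and how large its effect would be.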